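A few compounds are considered here, and "the series" means these few. Any claim that something is new, unique, unknown or untested is made for them only; others in the source may bear on it.

Measured in an ADME assay on HepG2 cells (Homo sapiens) for cytotoxicity, read by MTT assay, with a stated time of 72 h; on this read-out higher numbers stand for lower toxicity in this test and lower numbers for higher toxicity in this test:
- Compound 1 `O=[N+]([O-])c1c(CS(=O)(=O)c2ccccc2)nc2c(Br)cc(C(F)(F)F)cn12`: > 15600 nM (a limit)
- Compound 2 `Cc1nc2c(Br)cc(Cl)cn2c1[N+](=O)[O-]`: > 125000 nM (a limit)
- Compound 3 `O=[N+]([O-])c1c(CS(=O)(=O)c2ccccc2)nc2c([Se]c3ccc(Cl)cc3)cc(Cl)cn12`: > 7800 nM (a limit)

Compound 3 stands only at > 7800 nM, which is a limit and not a number. The other two values are limits as well, so no measured number is available as an anchor.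

Compound 4 `COc1ccc(Nc2cc(Cl)cn3c([N+](=O)[O-])c(CS(=O)(=O)c4ccccc4)nc23)cc1` carries one change from compound 3: a group of 9 heavy atoms (7 carbon, 1 nitrogen, 1 oxygen; one six-membered aromatic ring of carbon only) in place of a group of 8 heavy atoms (6 carbon, 1 chlorine, 1 selenium; one six-membered aromatic ring of carbon only), on an aromatic carbon. Among the measured compounds shown here, no measured pair shows what such a change does in this assay. A small upward step is expected, perhaps none beyond the scatter, and the result may again be only a limit. The expected change is a step that the limit leaves unreadable from compound 3 to compound 4. For compound 4 the estimate is 16000 nM, with an expected range of 6000 nM to 60000 nM.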

Compound 4, half-maximal cytotoxic concentration: > 3900 nM
Compound 4 was reported as a limit; the forecaster's own chance of this, stated with the estimate: 65%; the middle value is on the limit's open side.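

In this assay, compound 3 gives > 7800 nM, a limit. Compound 4 gives > 3900 nM, also a limit, so no step can be read between these two compounds. The compounds shown leave open at what concentration any of them becomes cytotoxic.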